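The source may hold more compounds than are shown below. What is called first, only, known or untested is meant among the compounds shown, and "the series" means these compounds.

Compound 1 `COc1ccc(-c2cc(/C=C/C(=O)c3ccc(N)cc3)[nH]n2)cc1` and compound 3 `COc1ccc(-c2cc(/C=C/C(=O)c3ccc(N)cc3)[nH]n2)cc1OC` share one core; in a functional assay on Hs-578T cells (Homo sapiens) for cytotoxicity, read by sulforhodamine B assay, with a stated time of 48 h, tested at 0.01 uM (on this read-out higher numbers stand for a weaker effect at the one concentration tested and lower numbers for a stronger effect), compound 1 gives 98% and compound 3 gives 98%. The change between them is methoxy in place of hydrogen on an aromatic carbon, and it produced the step of no change at the digits printed from compound 1 to compound 3 (within the scatter). Compound 2 `COc1ccc(C(=O)/C=C/c2cc(-c3cc(OC)c(OC)c(OC)c3)n[nH]2)cc1OC` rests on another core; the difference between the two cores is not broken down here. In this assay compound 2 gives 98%, level with compounds 1 and 3. Compound 4 `COc1cc(C(=O)/C=C/c2cc(-c3cc(OC)c(OC)c(OC)c3)n[nH]2)cc(OC)c1OC` has not yet been measured. It differs from compound 2 by methoxy in place of hydrogen on an aromatic carbon, the same kind of change as that made from compound 1 to compound 3, though here the place is also meta to a methoxy group. Because the earlier change produced no change at the digits printed from compound 1 to compound 3 (within the scatter), a like step is expected here, no change at the digits printed from compound 2 to compound 4 (within the scatter). Compound 4 is therefore estimated at 98% in this assay.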

Compound 4, a percentage reported as activity, at one concentration (the size of the read-out at that concentration, not a potency): 93%
Beside the measured number, compound 4's estimate is 5 percentage points above it; the measured number falls inside the stated range.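

In this assay, methoxy in place of hydrogen on an aromatic carbon gave a number 5 percentage points lower from compound 2 to compound 4 (within the scatter). Set beside the earlier step, the change reads alike on the two cores: the same change on two cores in this assay, no change at the digits printed (within the scatter) from compound 1 to compound 3 and a number 5 percentage points lower (within the scatter) from compound 2 to compound 4, 5 percentage points apart, within the scatter of two such steps This does not show that the change is without effect in general, since all four compounds stand at the weak end of the read-out at the one concentration tested, and two pairs say nothing about a compound with a stronger effect or about other cores.

The compounds shown leave open whether a hydroxyl group, a fluorine atom or a longer alkoxy chain at that place would read any differently. They also leave open how these pairs would compare at higher concentrations.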